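Replacing a saturated ring with an aromatic one on the amine

A few compounds are considered here, and "the series" means these few. Any claim that something is new, unique, unknown or untested is made for them only; others in the source may bear on it.

Of the compounds shown here, three sharing one core have been measured in a functional assay on CHO-K1 cells for antagonist activity at transient receptor potential cation channel subfamily V member 1 (Homo sapiens), read by FLIPR; on this read-out higher numbers stand for weaker inhibition and lower numbers for stronger inhibition. Compound 1 `CC1CCC(Nc2nc(C(F)(F)F)ccc2CNC(=O)C(C)c2ccc(NS(C)(=O)=O)c(F)c2)CC1` gives 27.2 nM. Compound 2 `CC(C(=O)NCc1ccc(C(F)(F)F)nc1NCC1CCN(C(=O)OC(C)(C)C)CC1)c1ccc(NS(C)(=O)=O)c(F)c1` gives 19.3 nM, and compound 3 `CC(C(=O)NCc1ccc(C(F)(F)F)nc1Nc1ccc(F)cc1)c1ccc(NS(C)(=O)=O)c(F)c1` gives 39.2 nM. Compound 1 sits second highest of the three numbers, but its gaps to both neighbours fall within the scatter, so the three cannot be ordered with confidence.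

Compound 4 `Cc1ccc(Nc2nc(C(F)(F)F)ccc2CNC(=O)C(C)c2ccc(NS(C)(=O)=O)c(F)c2)cc1C` differs from compound 1 in one place: 3,4-dimethylphenyl in place of 4-methylcyclohexyl on a nitrogen on an aromatic ring. For the measured compounds named here, one measured step bears on this. It swaps the same saturated ring for an aromatic ring on the same nitrogen, and there the number moved a 1.4-fold higher number from compound 1 to compound 3 (0.16 log units; within the scatter). Going by the values given here, that step stayed within the scatter, so exchanging a saturated ring for an aromatic one at this position has so far left this assay unchanged, and the two extra methyl groups of compound 4 have no measured precedent here.

The expectation is therefore a step of a 1.1-fold higher number from compound 1 to compound 4 (0.04 log units; within the scatter), no more than the scatter. Compound 4 is estimated at 30 nM, within a range of 12 nM to 75 nM.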

Compound 4, inhibition constant: 39.3 nM
Beside the measured number, compound 4's estimate is 1.3-fold (0.12 log units) below it; measured number inside the range.
By their numbers in this assay, from the lowest: compounds 2, 1, 3 and 4 (each within the scatter of the next, the first and the last beyond it).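

In this assay, a second aromatic ring on this nitrogen reads like the first: putting 3,4-dimethylphenyl in place of 4-methylcyclohexyl gives a 1.4-fold higher number from compound 1 to compound 4 (0.16 log units; within the scatter), a step of the same size as the one seen with 4-fluorophenyl. The two aromatic groups can now be compared directly, and the exchange gives a 1.0-fold higher number from compound 3 to compound 4 (0.00 log units; within the scatter), so two methyl groups and a single fluorine on the ring cannot be told apart at this position. Nothing available explains this sameness.

Still open, from the compounds shown here alone, is whether the number would stay in this range with a carboxylic acid or an amine on the aromatic ring. Going by these compounds, a plain ethyl chain on the nitrogen, with no ring at all, is an equally open case.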